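Fluoro for hydrogen: from compound 2 to compound 4

The source may hold more compounds than are shown below. What is called first, only, known or untested is meant among the compounds shown, and "the series" means these compounds.

Compound 2 `Nc1cccn2cc(Cc3ccccc3)c(=O)nc12` is the reference point of the series. In a functional assay on A549 cells (Homo sapiens) for cytotoxicity, read by MTT assay, with a stated time of 24 h (on this read-out higher numbers stand for weaker inhibition and lower numbers for stronger inhibition), compound 2 gives 98000 nM, the only numerical result in the set. The other two results are limits. Compound 1 `Nc1cc(Br)cn2cc(Cc3ccccc3)c(=O)nc12` returns only a limit, > 1000000 nM. Compound 3 `O=c1nc2ccc(Cl)cn2cc1Cc1ccc([N+](=O)[O-])cc1` likewise returns only a limit, > 1000000 nM. For the measured compounds named here, the single computed step, an at least 10-fold lower number from compound 1 to compound 2 (1.00 log units; beyond the scatter), is therefore anchored at the limit of > 1000000 nM in this assay, at which 2 of the 3 values shown sit, and carries no upper bound on its own size.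

Compound 4 `Nc1cccn2cc(Cc3ccc(F)cc3)c(=O)nc12` differs from compound 2 by fluoro in place of hydrogen on an aromatic carbon. Going by the values given here, no measured step bears directly on this change: the step from compound 1 to compound 2 concerns a different ring and a different group, and compound 3, which sits at a limit where compound 2 gives a number, differs from compound 2 in more than one place at once. With one fluorine entering, no ring added and no change in donor or acceptor count, the expected step of a 1.0-fold higher number from compound 2 to compound 4 (0.01 log units; within the scatter) is none beyond the scatter. Compound 4 is estimated at 100000 nM, with a range from 40000 nM to 250000 nM.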

Compound 4, half-maximal inhibitory concentration: > 1000000 nM
Compound 4: no number, only a limit (the forecaster's own chance of this, stated with the estimate: 20%); middle value at least 10-fold (1.00 log units) from the limit.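

On an aromatic carbon of the six-membered aromatic ring of carbon only, para to a large group, a single fluoro in place of hydrogen moves the read-out in this assay, giving an at least 10-fold higher number from compound 2 to compound 4 (1.00 log units; beyond the scatter). For the compounds shown here, the only earlier step concerned bromo on a different ring, so this is the first sign that this second position also responds to a one-atom change. Compound 4 returns only a limit, > 1000000 nM, which leaves compound 2 as the one compound in the series with a number: the limit of > 1000000 nM in this assay, at which 3 of the 4 values shown sit.

From the compounds shown here alone, how far compound 4 lies past its limit remains open, so the true size of the step cannot be read. Going by these compounds, it is also open whether a methyl or methoxy group at this position would give a number or the same limit.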